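Compound 3 to compound 4: changing the amide-type nitrogen group

The source may hold more compounds than are shown below. What is called first, only, known or untested is meant among the compounds shown, and "the series" means these compounds.

In a physicochemical assay for solubility (a lower number here means a less soluble compound, a higher number a more soluble compound), compound 3 `CNC(=O)c1cc(C(=O)NC)c2c(c1)[C@](C)(c1ccccc1)CO2` gives >= 132 ug/mL, which is a limit and not a number. Compound 2 `CNC(=O)c1cc(C(=O)NC2CC2)cc2c1OC[C@@]2(C)c1ccccc1` gives >= 138 ug/mL, also a limit. Compound 1 `CNC(=O)c1cc(C(=O)N[C@H]2CC[C@H](O)CC2)cc2c1OC[C@@]2(C)c1ccccc1` gives >= 161 ug/mL, again a limit. Compound 4 `CNC(=O)c1cc(C(=O)N[C@H]2[C@@H]3C[C@@H](O)C[C@@H]32)cc2c1OC[C@@]2(C)c1ccccc1` differs from compound 3 by a group of 7 heavy atoms (6 carbon, 1 oxygen; one three-membered non-aromatic ring of carbon only, one five-membered non-aromatic ring of carbon only) in place of one carbon atom, on an amide-type nitrogen. The measured changes at that nitrogen are a step that the two limits leave unreadable from compound 1 to compound 3, a step that the two limits leave unreadable from compound 2 to compound 3 and a step that the two limits leave unreadable from compound 1 to compound 2, so none offers a readable size. The closest guide is compound 1, whose 4-hydroxycyclohexyl group also replaces methyl in a step that the two limits leave unreadable from compound 1 to compound 3. The expected change is a step that the limit leaves unreadable from compound 3 to compound 4, with no step beyond the scatter and no direction anticipated. For compound 4 the estimated value is 150 ug/mL, with an expected range of 90 ug/mL to 210 ug/mL.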

Compound 4, solubility: >= 209 ug/mL
Compound 4: a limit, no number; the forecaster's own chance of this, stated with the estimate: 75%; middle value at least 1.3-fold (0.14 log units) away from the limit.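

In this assay, compound 4 is again only a limit, so its steps from compound 1, compound 2 and compound 3 cannot be read. The compounds shown leave open whether the groups on the amide-type nitrogen differ at all in this assay.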